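This account rests on a few compounds, and the source may have more. Where it says the series, first, only, none or still open, it means among the compounds named here.

Compound 1 `CC(C)Cc1ccc2c(NCCCNCc3ccco3)ccnc2c1`: 16000 nM
Compound 2 `COc1ccc(Oc2ccc3c(NCCCNCc4ccco4)ccnc3c2)cc1`: 5300 nM
Compound 3 `FC(F)(F)c1ccc(-c2ccc3c(NCCCNCc4ccco4)ccnc3c2)cc1`: 3470 nM

In an ADME assay on HepG2 cells (Homo sapiens) for cytotoxicity, read by luminescence, CellTiter-Glo and ATP content, with a stated time of 72 h (on this read-out higher numbers stand for an effect only at larger amounts of compound and lower numbers for an effect already at smaller amounts), compound 3 stands at the lowest of the three numbers: its step from compound 1, a 4.6-fold lower number from compound 1 to compound 3 (0.66 log units; beyond the scatter), lies beyond the scatter, while the step of a 1.5-fold lower number from compound 2 to compound 3 (0.18 log units; within the scatter) lies within it. Compound 4 `CC(C)(C)c1ccc(-c2ccc3c(NCCCNCc4ccco4)ccnc3c2)cc1` differs from compound 3 by tert-butyl in place of trifluoromethyl on an aromatic carbon. Among the measured compounds shown here, no measured step touches this exchange directly; the steps of a 3.0-fold lower number from compound 1 to compound 2 (0.48 log units; beyond the scatter) and a 4.6-fold lower number from compound 1 to compound 3 (0.66 log units; beyond the scatter) swap whole groups on an aromatic carbon and bear on it only loosely. The exchange is therefore expected to give a 1.0-fold higher number from compound 3 to compound 4 (0.00 log units; within the scatter), a step within the scatter. Compound 4 is accordingly estimated at 3500 nM, within 1500 nM to 8000 nM.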

Compound 4, half-maximal effective concentration: 3150 nM
Beside the measured number, compound 4's estimate is 1.1-fold (0.05 log units) above it; low and high end bracket the measured number.
By their numbers in this assay, from the lowest: compounds 4, 3 and 2 (each within the scatter of the next); then compound 1.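

In this assay, tert-butyl in place of trifluoromethyl on an aromatic carbon para to a large group stays within the scatter (a 1.1-fold lower number from compound 3 to compound 4 (0.04 log units; within the scatter)), so these two groups of four heavy atoms read alike at this place. The change from 4-methoxyphenoxy to 4-(tert-butyl)phenyl also stays within it (a 1.7-fold lower number from compound 2 to compound 4 (0.23 log units; within the scatter)), whereas the change from isobutyl lies beyond it (a 5.1-fold lower number from compound 1 to compound 4 (0.71 log units; beyond the scatter)). Nothing available explains these numbers. Going by these compounds, whether an amine or a carboxylic acid at this place would give a similar read-out remains open. So does the effect of changing the shared side chain.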